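From a Phenoxy to an Isopropoxy Substituent

The source may report more compounds than this note shows. Statements on the series, on what has been measured and on what is new or still open speak of the compounds shown alone.

Compounds measured so far in an in vitro functional assay on SH-EP1 cells for agonist activity at Neuronal acetylcholine receptor; alpha4/beta2 (Homo sapiens), read by FLIPR and calcium flux; on this read-out higher numbers stand for an effect only at larger amounts of compound and lower numbers for an effect already at smaller amounts:
- compound 1, `CN1CC2C=C(c3ccc(F)nc3)CC(C2)C1`: > 10000 nM
- compound 2, `COc1ccc(C2=CC3CC(C2)CN(C)C3)cn1`: > 10000 nM
- compound 3, `C1=C(c2cncc(Oc3ccccc3)c2)CC2CNCC1C2`: 654 nM

Compound 3 holds the only numerical result here; the other two readings are limits of the assay. Compound 1 sits at a limit, > 10000 nM. Compound 2 likewise sits at a limit, > 10000 nM. The step from compound 1 to compound 2, a methoxy in place of fluoro on an aromatic carbon, therefore cannot be sized: a step that the two limits leave unreadable from compound 1 to compound 2, because of the limit of > 10000 nM in this assay, at which 2 of the 3 values shown sit.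

Compound 4, `CC(C)Oc1cncc(C2=CC3CNCC(C2)C3)c1`, differs from compound 3 by isopropyl in place of phenyl on an oxygen on an aromatic ring. Among the compounds with values here, no measured step shows the effect of trading a phenyl for an isopropyl on that oxygen, so nothing here sets its size. Compounds 1 and 2, which carry small substituents on the aromatic ring but also a methyl on the nitrogen of the core, both sit at the limit, which leaves the direction open. The estimate for compound 4 is 2000 nM, with a range from 400 nM to 10000 nM. That estimate means an expected step of a 3.1-fold higher number from compound 3 to compound 4 (0.49 log units; beyond the scatter), a loss of potency that may or may not exceed the scatter.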

Compound 4, half-maximal effective concentration: 562 nM
Estimate against measurement, compound 4: 3.6-fold (0.55 log units) above; measured number inside the range.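

In this assay, the first step that can be read among these compounds is a 1.2-fold lower number from compound 3 to compound 4 (0.07 log units; within the scatter). On this oxygen, then, the six-membered aromatic ring of the phenyl is not needed for a reading of this order: the isopropyl, with no ring and fewer heavy atoms, gives a value that cannot be told apart from that of the phenyl. Nothing shown here gives a reason for this result, so the near-equal values stand without a cause.

Within the data shown here, the only earlier step, from compound 1 to compound 2, cannot be read, so it adds no information about how the group on this oxygen affects the reading. From the compounds shown here alone, it remains open whether an ethyl, a longer chain such as n-butyl, or a cyclohexyl on this oxygen would keep the value or move it beyond the scatter.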